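Fluoro to bromo in a small antiproliferative series

The source may hold more compounds than are shown below. What is called first, only, known or untested is meant among the compounds shown, and "the series" means these compounds.

compound 1 `COc1ccc(C(=O)/C=C/c2cc(Cl)cc(Cl)c2Oc2c([N+](=O)[O-])cc(C(F)(F)F)cc2[N+](=O)[O-])cc1` gives 2.69 ug/mL
compound 2 `O=C(/C=C/c1cc(Cl)cc(Cl)c1Oc1c([N+](=O)[O-])cc(C(F)(F)F)cc1[N+](=O)[O-])c1ccc(F)cc1` gives 5.02 ug/mL
compound 3 `O=C(/C=C/c1cccc(Cl)c1Oc1c([N+](=O)[O-])cc(C(F)(F)F)cc1[N+](=O)[O-])c1ccc(F)cc1` gives 5.17 ug/mL

In a functional assay on MCF7 cells (Homo sapiens) for antiproliferative activity, read by MTT assay, with a stated time of 48 h (a lower number here means a stronger inhibitor, a higher number a weaker inhibitor), compound 2 gives 5.02 ug/mL and lies within the usual scatter of both other measured compounds, so no firm ranking can be drawn for it. Compound 4 `O=C(/C=C/c1cc(Cl)cc(Cl)c1Oc1c([N+](=O)[O-])cc(C(F)(F)F)cc1[N+](=O)[O-])c1ccc(Br)cc1` differs from compound 2 in one place, with bromo in place of fluoro on an aromatic carbon as the count of the change: bromo in place of fluoro on an aromatic carbon, para to a large group. In other words, 4-fluorophenyl becomes 4-bromophenyl.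

Within the data shown here, two measured steps bear on this. Fluoro in place of methoxy involves the same fluoro group and shows a 1.9-fold higher number from compound 1 to compound 2 (0.27 log units; within the scatter) on the read-out. Hydrogen in place of chloro shows a 1.0-fold higher number from compound 2 to compound 3 (0.01 log units; within the scatter) on the same read-out. Among the measured compounds shown here, neither step goes beyond the scatter, and no measured compound carries bromo, so this swap has no direct test yet. No step beyond the scatter is therefore expected in this assay for this change. The expected step is a 1.1-fold lower number from compound 2 to compound 4 (0.05 log units; within the scatter) and it remains an estimate. For compound 4 the estimated value is 4.5 ug/mL with an expected range from 2.1 ug/mL to 9.5 ug/mL as the likely span of a measurement.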

Compound 4, half-maximal inhibitory concentration: 2.6 ug/mL
The estimate for compound 4 lay 1.7-fold (0.24 log units) above the measured number; low and high end bracket the measured number.
By their numbers in this assay, from the lowest: compounds 4, 1, 2 and 3 (each within the scatter of the next).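

In this assay, among these compounds, the first bromo group at this position gives a 1.9-fold lower number from compound 2 to compound 4 (0.29 log units; within the scatter), so 4-bromophenyl cannot be told apart from 4-fluorophenyl here. Against the methoxy group, bromo gives a 1.0-fold lower number from compound 1 to compound 4 (0.01 log units; within the scatter), which means that methoxy, fluoro and bromo on this aromatic carbon now all lie within the scatter of one another, and this assay does not rank them. Nothing available explains these numbers.

As far as these compounds go, it remains open whether a group of another kind on this carbon, such as an amine or a carboxylic acid, would give a step beyond the scatter. From the compounds shown here alone, it is also open whether bromo would give a similar number on the core of compound 3, which carries hydrogen in place of one chloro.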